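The source may hold more compounds than are shown below. What is called first, only, known or untested is meant among the compounds shown, and "the series" means these compounds.

Compound 1 `O=C(COCc1ccccc1)N1CCN(c2ccccc2)CC1` and compound 2 `O=C(COCc1ccccc1)N1CCN(c2ccccc2Cl)CC1` share the same core. In an in vitro ADME assay on microsomes from liver (Homo sapiens) for metabolic stability (a lower number here means slower removal, a higher number faster removal of the compound), compound 1 stands as "not determined" (no result reported), so it offers no number to compare against. Among the measured compounds shown here, compound 2 gives 540 mL.min-1.g-1, the only number available, so it cannot yet be ranked against any close relative. Compound 3 `O=C(COCc1ccccc1)N1CCN(c2cccc(Cl)c2)CC1` has the same atoms joined differently, with 3-chlorophenyl in place of 2-chlorophenyl on an amine nitrogen in a ring. For the measured compounds named here, no pair of measured compounds here shows what such a swap does, so the single reading for compound 2 is the only anchor. No change beyond the usual scatter of this assay is expected, and neither direction is favoured. The expected step is no change at the digits printed from compound 2 to compound 3 (within the scatter). For compound 3 the estimate is 540 mL.min-1.g-1, with an expected range from 270 mL.min-1.g-1 to 1080 mL.min-1.g-1.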

Compound 3, intrinsic clearance in microsomes: 310 mL.min-1.g-1
Estimate against measurement, compound 3: 1.7-fold (0.24 log units) above; measured number inside the range.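

In this assay, placing 3-chlorophenyl where 2-chlorophenyl stood on the amine nitrogen in a ring gives a 1.7-fold lower number from compound 2 to compound 3 (0.24 log units; within the scatter). Among the compounds shown here, this is the first step that can be read, and it shows that the swap leaves the read-out within the normal spread of repeat measurements, so compound 2 and compound 3 cannot be told apart here. No measured evidence is available to account for the two readings.

Steps involving compound 1 cannot be read, so what the chlorine itself contributes, compared with the plain phenyl group, remains unknown. From the compounds shown here alone, it also remains open whether a different group at the same place, such as a pyridyl or methoxyphenyl group, would shift the number beyond that spread.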